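Ethyl for Methyl on the Nitro Analogue

The source may hold more compounds than are shown below. What is called first, only, known or untested is meant among the compounds shown, and "the series" means these compounds.

Compound 1, `CCn1c(/C=C2/C(=O)Nc3ccc(F)cc32)nc2ccccc21`: in a functional assay on BT-549 cells (Homo sapiens) for cytotoxicity, read by MTT assay, with a stated time of 48 h (a lower number here means a stronger inhibitor, a higher number a weaker inhibitor), compound 1 gives > 50000 nM, which is a limit of the assay and not a number.
Compound 2, `CCn1c(/C=C2/C(=O)Nc3ccc(C)cc32)nc2ccccc21`: compound 2 gives > 50000 nM, again a limit rather than a number.
Compound 3, `Cn1c(/C=C2/C(=O)Nc3ccc([N+](=O)[O-])cc32)nc2ccccc21`: compound 3 gives "not determined" (no result reported), so no result is reported for it.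

Compound 3 therefore has no place on the numbers: it carries no value of its own, and the two other values shown are limits, as the line the limit of > 50000 nM in this assay, at which 2 of the 3 values shown sit, records. Compound 4, `CCn1c(/C=C2/C(=O)Nc3ccc([N+](=O)[O-])cc32)nc2ccccc21`, differs from compound 3 in one spot: methyl in place of hydrogen on a saturated chain carbon bound to an aromatic nitrogen, or, cut one bond further out, methyl to ethyl. For the measured compounds named here, the only measured step, a step that the two limits leave unreadable from compound 1 to compound 2, exchanges a group on an aromatic carbon, not on the chain carbon, and its size the two limits leave unreadable. So no measured step bears on the change from compound 3 to compound 4, and no direction can be called. Since two of three values sit at the limit (the limit of > 50000 nM in this assay, at which 2 of the 3 values shown sit), a limit is the likeliest outcome for compound 4 as well. Compound 4 is expected to give about 50000 nM, within a range from 10000 nM to 100000 nM.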

Compound 4, half-maximal inhibitory concentration: > 50000 nM
Compound 4 was reported as a limit (the forecaster's own chance of this, stated with the estimate: 75%); the middle value sits exactly at the limit.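

Compound 4 sits at the same limit as compound 1 and compound 2, so the steps among these three cannot be read and no new step comes from this result in this assay: the limit of > 50000 nM in this assay, at which 3 of the 4 values shown sit. The compounds shown leave open whether fluoro, methyl or nitro on the aromatic carbon, or methyl to ethyl on the chain, changes cytotoxicity at all.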